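The compounds below may be only part of what the source reports. "The series", "measured", "known", "first", "only" and "open" are said of these compounds alone.

Compound 3 `COc1ccccc1-c1cc(N2CCC(CNS(N)(=O)=O)CC2)ncn1` carries a 2-methoxyphenyl on the shared core. In a functional assay on MDA-MB-468 cells (Homo sapiens) for antiproliferative activity (on this read-out lower numbers stand for stronger inhibition of growth and higher numbers for weaker inhibition of growth), compound 3 gives > 100000 nM, which is a limit of the assay and not a number. Two close relatives are measured beside it: compound 1 `NS(=O)(=O)NCC1CCN(c2cc(-c3ccccc3)ncn2)CC1` lacks the methoxy, and compound 2 `COc1ccc(-c2cc(N3CCC(CNS(N)(=O)=O)CC3)ncn2)cc1` carries a 4-methoxyphenyl instead. In this assay compound 1 gives > 100000 nM, a limit. Compound 2 gives > 100000 nM, again a limit. Every measured value thus sits at the limit of > 100000 nM in this assay, at which 3 of the 3 values shown sit, and the steps a step that the two limits leave unreadable from compound 1 to compound 2, a step that the two limits leave unreadable from compound 1 to compound 3 and a step that the two limits leave unreadable from compound 2 to compound 3 cannot be read in size or direction.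

Compound 4 `NS(=O)(=O)NCC1CCN(c2cc(-c3ccccc3Cl)ncn2)CC1` differs from compound 3 by chloro in place of methoxy on an aromatic carbon. Among the compounds with values here, none of the measured steps gives a readable size for a change of this kind, and every compound that shares the core has so far stayed at the limit. Compound 4 is therefore expected to give no measurable value either, the expected step being a number no higher from compound 3 to compound 4 (the limit leaves the size open). The estimate for compound 4 is 100000 nM, expected between 30000 nM and 300000 nM.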

Compound 4, concentration for 50% growth inhibition: > 100000 nM
Compound 4 was reported as a limit (the forecaster's own chance of this, stated with the estimate: 85%); the middle value sits exactly at the limit.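

Compound 4 stays at the same limit as compound 1, compound 2 and compound 3, so none of its steps to them can be read in size or direction: the limit of > 100000 nM in this assay, at which 4 of the 4 values shown sit.

The compounds shown leave open how hydrogen, methoxy and chloro on an aromatic carbon compare in this assay.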